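A chloro group on the phenyl of compound 1

This account rests on a few compounds, and the source may have more. Where it says the series, first, only, none or still open, it means among the compounds named here.

In a functional assay on DU-145 cells (Homo sapiens) for antiproliferative activity, read by MTT assay, with a stated time of 24 h (on this read-out higher numbers stand for weaker inhibition and lower numbers for stronger inhibition), compound 1 (`COc1ccc(-c2noc(-c3ccccc3)n2)cc1OC1CCCC1`) reads > 1000000 nM as its result, and this is a limit of the assay and not a number. Compound 3 (`COc1ccc(-c2noc(-c3cccnc3)n2)cc1OC1CCCC1`) likewise reads > 1000000 nM as a limit. Compound 2 (`COc1ccc(-c2noc(C3CCCN3)n2)cc1OC1CCCC1`) gives a real number of 242000 nM in this assay as its result. Compound 1 therefore stands at the limit of > 1000000 nM in this assay, at which 2 of the 3 values shown sit, and not at a measured point.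

Compound 4 (`COc1ccc(-c2noc(-c3ccc(Cl)cc3)n2)cc1OC1CCCC1`) is compound 1 with chloro in place of hydrogen on an aromatic carbon, which turns phenyl into 4-chlorophenyl: chloro in place of hydrogen on an aromatic carbon is the full count.

Going by the values given here, no measured step tests chloro. The nearest evidence swaps the whole phenyl group. Replacing phenyl with pyrrolidin-2-yl gave an at least 4.1-fold lower number from compound 1 to compound 2 (0.61 log units; beyond the scatter) as the one readable gain. Replacing phenyl with pyridin-3-yl gave a step that the two limits leave unreadable from compound 1 to compound 3 and nothing more can be read from it. Going from pyrrolidin-2-yl to pyridin-3-yl gave an at least 4.1-fold higher number from compound 2 to compound 3 (0.61 log units; beyond the scatter) in the opposite direction.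

The gain in an at least 4.1-fold lower number from compound 1 to compound 2 (0.61 log units; beyond the scatter) came with losing the phenyl group, which compound 4 keeps, so no step beyond the scatter is expected in this assay and another limit is the likeliest report. The expected step is a number no higher from compound 1 to compound 4 (the limit leaves the size open) by this estimate. For compound 4 the estimated value is 1000000 nM with an expected range from 200000 nM to 3000000 nM in this estimate.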

Compound 4, half-maximal inhibitory concentration: 123000 nM
Compound 4: the middle estimate sits 8.1-fold (0.91 log units) above what was measured; the measured number lies below the stated range.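

Keeping the phenyl and adding a single chloro, para to a large group, is enough to move the result off the limit in this assay, with an at least 8.1-fold lower number from compound 1 to compound 4 (0.91 log units; beyond the scatter). The 4-chlorophenyl group also stands clear of the pyridin-3-yl group, with an at least 8.1-fold lower number from compound 3 to compound 4 (0.91 log units; beyond the scatter), whereas against the pyrrolidin-2-yl group there is a 2.0-fold lower number from compound 2 to compound 4 (0.29 log units; within the scatter), so two very different groups at this place cannot be told apart here, and losing the phenyl is not the only route to a measured number. The first two of these steps start from a limit and not a number, so they give only a smallest possible size and the true size stays open: the limit of > 1000000 nM in this assay, at which 2 of the 4 values shown sit.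

Going by these compounds, whether this shift belongs to chlorine in particular stays open, since fluoro, methyl or methoxy at the same place, or chloro elsewhere on the phenyl, would separate the effect of the atom from the effect of its place. On these data alone, it is equally open whether an amine or a carboxylic acid on this phenyl would move the number further or return it to the limit.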